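Cycloalkyl ether series: cell toxicity notes

This account rests on a few compounds, and the source may have more. Where it says the series, first, only, none or still open, it means among the compounds named here.

Values in an ADME assay on MDBK cells (Bos taurus) for cytotoxicity, read by MTT assay; on this read-out lower numbers stand for higher toxicity in this test and higher numbers for lower toxicity in this test:
compound 1 `CC1CC(OCCCCCCN2C[C@H](O)[C@@H](O)[C@H](O)[C@H]2CO)CC(C)(C)C1`: 250000 nM
compound 2 `OC[C@@H]1[C@@H](O)[C@H](O)[C@@H](O)CN1CCCCCCOC1CCCCC1C1CCCCC1`: 200000 nM

Compound 1 gives the highest of the two numbers in this assay; compound 2 sits a little lower, but the gap between them lies within the usual scatter, so no order between the two can be read from these numbers. Both sit at the weakly toxic end of the scale.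

Compound 3 `CCC1CCC(OCCCCCCN2C[C@H](O)[C@@H](O)[C@H](O)[C@H]2CO)CC1` has not yet been measured. Relative to compound 1 the change is 4-ethylcyclohexyl in place of 3,3,5-trimethylcyclohexyl on an oxygen on a saturated carbon. The group that leaves and the group that enters are both a six-membered non-aromatic ring of carbon only, with no hydrogen-bond donors or acceptors on either side, and the attachment through the oxygen on the saturated carbon is unchanged. Among the measured compounds shown here, no measured pair shows such an exchange, so the size of its effect cannot be taken from data.

With compound 1 and compound 2 so close, a step within the scatter is expected: a 1.1-fold lower number from compound 1 to compound 3 (0.06 log units; within the scatter). Compound 3 is estimated at 220000 nM in this assay, with a range from 100000 nM to 450000 nM.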

Compound 3, half-maximal cytotoxic concentration: > 500000 nM
Compound 3: a limit, no number; the forecaster's own chance of this, stated with the estimate: 30%; middle value at least 2.2-fold (0.35 log units) from the limit.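

In this assay compound 3 gives > 500000 nM, which is a limit of the assay and not a number. Among the compounds shown here, exchanging 3,3,5-trimethylcyclohexyl for 4-ethylcyclohexyl on an oxygen on a saturated carbon forms the first one-place pair and gives an at least 2.0-fold higher number from compound 1 to compound 3 (0.30 log units; that floor lies within the scatter). This position therefore accepts the exchange of one six-membered carbon ring for another with no sign of higher toxicity in this test, but the floor of the step does not clear the scatter and its true size stays unfixed: the limit of > 500000 nM in this assay, at which 1 of the 3 values shown sits.

For the compounds shown here, the single pair changes the ring's substituents all at once, so the effect of adding the 4-ethyl group cannot be separated from that of removing the three methyl groups. On these data alone, how an unsubstituted cyclohexyl, a phenyl ring, or a cyclohexyl carrying an amine or a carboxylic acid would read in this assay remains open, and so does whether any group at this position can bring the read-out down into a clearly more toxic range.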